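Swapping a methyl-bearing ring for a chlorine-bearing ring

The source may report more compounds than this note shows. Statements on the series, on what has been measured and on what is new or still open speak of the compounds shown alone.

Three compounds share one core, a succinimide-bearing chain joined to a piperazine that carries an aromatic ring, and differ only in that ring. Compound 1 `CCC(C(=O)N1CCN(c2cccc(OC)c2)CC1)N1C(=O)CCC1=O` carries a 3-methoxyphenyl group, compound 2 `CCC(C(=O)N1CCN(c2ccc(F)cc2)CC1)N1C(=O)CCC1=O` a 4-fluorophenyl group and compound 3 `CCC(C(=O)N1CCN(c2cccc(C)c2)CC1)N1C(=O)CCC1=O` a 3-methylphenyl group. In a functional assay on the whole organism (strain Swiss) with Mus musculus as the target, in the maximal electroshock model, with a stated time of 0.5 h, at a dose of 300 mg/kg by the intraperitoneal route (a lower number here means a weaker effect, a higher number a stronger effect of the compound at the dose given), compound 1 gives 0%, compound 2 gives 25% and compound 3 gives 100%, the highest of the three; the nearest, compound 2, lies well below it, as shown by a number 75 percentage points higher from compound 2 to compound 3 (beyond the scatter), and compound 1 lies furthest, as shown by a number 100 percentage points higher from compound 1 to compound 3 (beyond the scatter).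

Compound 4 `CCC(C(=O)N1CCN(c2ccc(Cl)cc2)CC1)N1C(=O)CCC1=O` is the next step: 4-chlorophenyl in place of 3-methylphenyl on an amine nitrogen in a ring. Within the data shown here, the step bearing most on it is the one already measured between compound 2 and compound 3, in which a 4-fluorophenyl group gave way to a 3-methylphenyl group and the read-out rose by a number 75 percentage points higher from compound 2 to compound 3 (beyond the scatter). Compound 4 returns to a halogen-bearing ring, and compound 2 shows how far such a ring fell short of compound 3; the smaller step of a number 25 percentage points higher from compound 1 to compound 2 (beyond the scatter) adds little more. A drop is therefore expected, though a chlorine is not a fluorine, so its size is uncertain. For compound 4 the expected outcome is 50%, within 10% to 100%, an estimated step of a number 50 percentage points lower from compound 3 to compound 4 (beyond the scatter).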

Compound 4, a percentage reported as activity, at one dose (the size of the read-out at that dose, not a potency): 0%
The estimate for compound 4 lay 50 percentage points above the measured number; the whole stated range lies above it.
By their numbers in this assay, from the lowest: compounds 1 and 4 (each within the scatter of the next); then compound 2; then compound 3.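

In this assay, moving to the 4-chlorophenyl group gives a number 100 percentage points lower from compound 3 to compound 4 (beyond the scatter), even though the two groups match in heavy-atom count, aromatic ring, hydrogen-bond donors and acceptors and net charge, so these computed counts do not follow the read-out here. Chloro in place of fluoro on an aromatic carbon gives a number 25 percentage points lower from compound 2 to compound 4 (beyond the scatter), which shows that one halogen cannot simply stand in for the other on this ring. The 4-chlorophenyl group in place of the 3-methoxyphenyl group gives no change at the digits printed from compound 1 to compound 4 (within the scatter), so two different aromatic groups can produce the same read-out at this dose, and among the four compounds only compound 3 has a read-out far above the rest.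

Nothing available explains why these groups differ so sharply in effect. Compound 3 and compound 4 differ in both the substituent and where it sits on the ring, so the compounds shown leave those two changes tangled, and a 3-chlorophenyl or 4-methylphenyl group would be the natural way to pull them apart.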